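A few compounds are considered here, and "the series" means these few. Any claim that something is new, unique, unknown or untested is made for them only; others in the source may bear on it.

Compound 2 `COc1cccc(OC/C=C(\C)CC/C=C(\C)C2CC(=O)C(C)(C)O2)c1` carries a 3-methoxyphenyl on the oxygen that hangs from a saturated carbon of the shared core. In a functional assay on FM3A cells (Mus musculus) for inhibition (on this read-out lower numbers stand for stronger inhibition and higher numbers for weaker inhibition), compound 2 gives 68.7 ug/mL, the larger of the two numbers recorded so far, though only within the scatter of the other. Among the compounds with values here, its sole measured neighbour is compound 1 `C/C(=C\COc1c(Cl)cccc1Cl)CC/C=C(\C)C1CC(=O)C(C)(C)O1`, which bears a 2,6-dichlorophenyl on that same oxygen; in this assay compound 1 gives 51.2 ug/mL. Within the data shown here, the one step between them, a 1.3-fold higher number from compound 1 to compound 2 (0.13 log units; within the scatter), shows that exchanging one aryl group for the other at that oxygen leaves the read-out essentially unmoved.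

Compound 3 `C/C(=C\COc1ccccc1)CC/C=C(\C)C1CC(=O)C(C)(C)O1` takes the next step away from compound 2: hydrogen in place of methoxy on an aromatic carbon, so that the aryl group becomes a plain phenyl. Among the measured compounds shown here, only the step from compound 1 to compound 2 bears on this change, and that step stayed within the scatter, so no shift beyond the scatter is expected in this assay here either; the step from compound 2 to compound 3 is expected to amount to a 1.1-fold lower number from compound 2 to compound 3 (0.06 log units; within the scatter). Compound 3 is therefore estimated to give about 60 ug/mL, within a range from 30 ug/mL to 120 ug/mL.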

Compound 3, half-maximal inhibitory concentration: 59 ug/mL
Compound 3: middle estimate off by 1.0-fold (0.01 log units), on the high side; low and high end bracket the measured number.
By their numbers in this assay, from the lowest: compounds 1, 3 and 2 (each within the scatter of the next).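

With the methoxy group gone and only hydrogen in its place on the aromatic carbon, this assay records a 1.2-fold lower number from compound 2 to compound 3 (0.07 log units; within the scatter), so this group can be removed without the read-out leaving the scatter. The plain phenyl also stays close to the doubly chlorinated aryl group, with a 1.2-fold higher number from compound 1 to compound 3 (0.06 log units; within the scatter), which shows that even an aryl group with no substituent at all cannot be told apart from the 3-methoxyphenyl and 2,6-dichlorophenyl groups on this oxygen in this assay; all three compounds lie within the scatter of one another, and none can be ranked above the others. Nothing available here offers an explanation for this flat read-out at the aryl group.

The compounds shown leave open whether any group on this aromatic ring can move the number beyond the scatter, for instance an amine or a carboxylic acid in place of the methoxy group. They also leave open whether replacing the aryl group altogether, with a longer chain on the same oxygen, would change the read-out in this assay.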